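Thiourea series: acetyl replacing bromo in peroxidase inhibition

The compounds below may be only part of what the source reports. "The series", "measured", "known", "first", "only" and "open" are said of these compounds alone.

Measured so far:
compound 1 `Oc1ccc(NC(=S)Nc2ccc3[nH]ccc3c2)cc1` gives 41.5%
compound 2 `S=C(Nc1ccc(Oc2ccccc2)cc1)Nc1ccc2[nH]ccc2c1` gives 73.1%
compound 3 `S=C(Nc1ccc(Br)cc1)Nc1ccc2[nH]ccc2c1` gives 82%

All three values come from an ADME assay on isolated protein for inhibition of peroxidase (Raphanus sativus), read by fluorescence and Amplex Red, tested at 5 uM; a lower number here means a stronger effect, a higher number a weaker effect of the compound at the concentration tested. Compound 3 has the highest number of the three: compound 2 is the nearest, and the step of a number 8.9 percentage points higher from compound 2 to compound 3 (within the scatter) is within the scatter, so no order between compound 3 and compound 2 is claimed. Compound 1 is furthest, with the step of a number 40.5 percentage points higher from compound 1 to compound 3 (beyond the scatter) beyond the scatter.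

Compound 4 `CC(=O)c1ccc(NC(=S)Nc2ccc3[nH]ccc3c2)cc1` is not yet measured. It differs from compound 3 as follows: acetyl in place of bromo on an aromatic carbon.

Among the compounds with values here, two measured steps bear on this change. The step of a number 40.5 percentage points higher from compound 1 to compound 3 (beyond the scatter) shows that hydroxy gives a much lower number than bromo in this assay, while a number 8.9 percentage points higher from compound 2 to compound 3 (within the scatter) shows phenoxy and bromo within the scatter of each other. Acetyl brings a hydrogen-bond acceptor but no donor, so it is unlike hydroxy and the change is expected to be modest, in the downward direction if at all.

For compound 4 the estimate is 68%, within 42% to 90%. The expected step for compound 4 is a number 14 percentage points lower from compound 3 to compound 4 (beyond the scatter).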

Compound 4, a percentage reported as activity, at one concentration (the size of the read-out at that concentration, not a potency): 66.3%
Compound 4: the middle estimate sits 1.7 percentage points above what was measured; measured number inside the range.
By their numbers in this assay, from the lowest: compound 1; then compounds 4, 2 and 3 (each within the scatter of the next, the first and the last beyond it).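

Replacing bromo with acetyl on an aromatic carbon para to a large group gives a step that stands clear of the scatter (a number 15.7 percentage points lower from compound 3 to compound 4 (beyond the scatter)). Within the data shown here, until now, the only steps beyond the scatter at this position involved hydroxy, so this result shows that a group other than hydroxy can also separate from bromo, while acetyl remains apart from hydroxy (a number 24.8 percentage points higher from compound 1 to compound 4 (beyond the scatter)). Acetyl and phenoxy cannot be ordered (a number 6.8 percentage points lower from compound 2 to compound 4 (within the scatter)), so compound 2 lies within the scatter of both compound 3 and compound 4, although those two are themselves separated.

No measurement at hand gives a cause for these steps. As far as these compounds go, it remains open whether an amine or a carboxylic acid at this position would come close to compound 1 or stay with compound 4.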